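The source may hold more compounds than are shown below. What is called first, only, known or untested is meant among the compounds shown, and "the series" means these compounds.

For the measured compounds named here, compound 2 `NS(=O)(=O)c1ccc(-c2nc(C(c3ccc(F)cc3)c3ccc(F)cc3)sc2CC(=O)O)cc1` stands highest of the three numbers measured so far in an in vitro functional assay on HEK285-7 cells for antagonist activity at prostaglandin D2 receptor 2 (Homo sapiens), read by BRET and beta-arrestin recruitment; a lower number here means a smaller maximal response, a higher number a larger maximal response: compound 2 gives 80%. Its nearest neighbour on that scale, compound 1 `O=C(O)Cc1sc(Cc2ccccc2-c2ccccc2)nc1-c1ccc(Cl)cc1`, gives 50% in this assay, and compound 3 `O=C(O)Cc1sc(Cc2ccccc2)nc1-c1ccc(Cl)cc1` gives 50%, each of them a gap beyond the scatter below compound 2. Going by the values given here, the only step measured between compounds that differ in one place is the one from compound 1 to compound 3, with hydrogen in place of phenyl on an aromatic carbon, and it shows no change at the digits printed from compound 1 to compound 3 (within the scatter). That change sits on the benzyl side of the shared core, not at the aryl group that is about to be exchanged.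

Compound 4 `Nc1cc(-c2nc(C(c3ccc(F)cc3)c3ccc(F)cc3)sc2CC(=O)O)cc(F)n1` differs from compound 2 by 2-amino-6-fluoropyridin-4-yl in place of 4-sulfamoylphenyl on an aromatic carbon. Among the compounds with values here, no measured step touches this place, so nothing tells how large an effect an aryl exchange there has. What the numbers do show is a spread in this assay from compound 3 and compound 1 up to compound 2. Compound 4 is therefore expected to give about 65% in this assay, within an estimated range from 45% to 90%. This amounts to an expected step of a number 15 percentage points lower from compound 2 to compound 4 (beyond the scatter).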

Compound 4, largest response reached (reported as efficacy), in percent of the reference or control that the assay uses: 30%
Compound 4: middle estimate off by 35 percentage points, on the high side; the whole stated range lies above it.
By their numbers in this assay, from the lowest: compound 4; then compounds 1 and 3 (each within the scatter of the next); then compound 2.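

Exchanging the aryl group on the aromatic carbon next to the ring nitrogen gives a number 50 percentage points lower from compound 2 to compound 4 (beyond the scatter) in this assay, the first measured sign that the maximal response in this series depends on the group at this place. The earlier single-place step, on the benzyl side, was no change at the digits printed from compound 1 to compound 3 (within the scatter), so the series now holds one change that leaves the number in place and one that moves it well beyond the scatter. The step also appears although the two groups have the same counts of hydrogen-bond donors and acceptors and neither carries a net charge, so those counts alone do not separate compound 2 from compound 4, and no measurement shown here accounts for the step.

The exchange replaces the whole aryl group at once, so the compounds shown leave open how much of the step belongs to the sulfamoyl group, the ring nitrogen, the amine or the fluorine. A 2-aminopyridin-4-yl group without the fluorine, or a 4-methylsulfonylphenyl group, at this same place would begin to divide the step among those parts.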